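A few compounds are considered here, and "the series" means these few. Any claim that something is new, unique, unknown or untested is made for them only; others in the source may bear on it.

Working notes on the series, read in a functional assay on MCF7 cells (Homo sapiens) for cytotoxicity, read by MTT assay, with a stated time of 24 h; on this read-out lower numbers stand for stronger inhibition and higher numbers for weaker inhibition. Compound 1 (`CCNc1cc(-c2ccc(NC(=O)Nc3ccc(C)cc3)cc2C)ccn1`) gives 9210 nM, compound 2 (`CCNc1cc(-c2ccc(NC(=O)Nc3ccc(OC)cc3)cc2C)ccn1`) gives 9950 nM and compound 3 (`CCNc1cc(-c2ccc(NC(=O)Nc3cccc4ccccc34)cc2C)ccn1`) gives 15500 nM. Compound 2 cannot be separated from either of the other two: a 1.1-fold higher number from compound 1 to compound 2 (0.03 log units; within the scatter) and a 1.6-fold higher number from compound 2 to compound 3 (0.19 log units; within the scatter) both lie within the scatter.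

Compound 4 (`CCNc1cc(-c2ccc(NC(=O)Nc3ccccc3Cl)cc2C)ccn1`) keeps the core of compound 2 and differs in one place: 2-chlorophenyl in place of 4-methoxyphenyl on an amide-type nitrogen. In words, this is 2-chlorophenyl in place of 4-methoxyphenyl on an amide-type nitrogen.

The closest evidence is the other exchanges on that nitrogen, a 1.7-fold higher number from compound 1 to compound 3 (0.23 log units; within the scatter) and a 1.6-fold higher number from compound 2 to compound 3 (0.19 log units; within the scatter), together with the methoxy for methyl exchange, a 1.1-fold higher number from compound 1 to compound 2 (0.03 log units; within the scatter). Among the compounds with values here, all three stay within the scatter, although no measured compound carries chlorine, so this is indirect evidence. No step beyond the scatter is therefore expected in this assay, and no direction can be favoured.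

The estimate amounts to a 1.0-fold higher number from compound 2 to compound 4 (0.00 log units; within the scatter), an expected step within the scatter. For compound 4 the expected value is 10000 nM, with an estimated range of 5000 nM to 19000 nM.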

Compound 4, half-maximal inhibitory concentration: 8350 nM
Beside the measured number, compound 4's estimate is 1.2-fold (0.08 log units) above it, and the stated range covers the measured number.
By their numbers in this assay, from the lowest: compounds 4, 1, 2 and 3 (each within the scatter of the next).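

In this assay, within the data shown here, 2-chlorophenyl on the amide-type nitrogen brings chlorine into the series for the first time, and all three of its steps stay within the scatter: a 1.2-fold lower number from compound 2 to compound 4 (0.08 log units; within the scatter), a 1.1-fold lower number from compound 1 to compound 4 (0.04 log units; within the scatter) and a 1.9-fold lower number from compound 3 to compound 4 (0.27 log units; within the scatter). The position therefore accepts a chlorine-bearing ring and the loss of the methoxy oxygen without a step beyond the scatter, and no order can be drawn among the four aryl groups on that nitrogen. No evidence on any measured property bears on this result.

The compounds shown leave open whether 4-chlorophenyl would read like 2-chlorophenyl, and whether a phenyl ring carrying a carboxylic acid or an amine would move the number beyond the scatter. They also leave open whether a saturated cyclohexyl group or a longer alkyl chain on that nitrogen would do so.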